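The compounds below may be only part of what the source reports. "The series", "measured", "known", "first", "only" and "open" are said of these compounds alone.

Compound 1: `CN(Cc1cc(C(F)(F)F)cc(C(F)(F)F)c1)C(=O)c1cnc2ccccc2c1-c1ccccc1` gives 92 nM in an assay on CHO cells for displacement of a labelled ligand from Substance-P receptor (Homo sapiens), with a stated time of 90 min; a lower number here means a stronger inhibitor, a higher number a weaker inhibitor.
Compound 2: `Cc1nccc(-c2ccccc2)c1C(=O)N(C)Cc1cc(C(F)(F)F)cc(C(F)(F)F)c1` gives 98 nM in this assay.
Compound 3: `Cc1c(C(=O)NCc2cc(C(F)(F)F)cc(C(F)(F)F)c2)c(-c2ccccc2)cc[n+]1[O-]` gives 342 nM in this assay.

Among these three numbers compound 2 stands second highest. Its nearest neighbour is compound 1, whose number is lower by a margin that lies within the scatter, so no order between the two can be drawn. Its furthest neighbour is compound 3, whose number is higher by a margin that lies beyond the scatter.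

Compound 4, `Cc1nc(Cl)cc(-c2ccccc2)c1C(=O)N(C)Cc1cc(C(F)(F)F)cc(C(F)(F)F)c1`, has not yet been measured. It differs from compound 2 in one place: chloro in place of hydrogen on an aromatic carbon. Within the data shown here, no step between two measured compounds shows what this change does, so the expectation rests on compound 2 alone and on the closeness of its value to that of compound 1. A small step, if any, is expected, most likely not beyond the scatter, with a slight lean towards a lower number. The expected step is a 1.2-fold lower number from compound 2 to compound 4 (0.09 log units; within the scatter). Compound 4 is therefore estimated at 80 nM, within a range from 30 nM to 250 nM.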

Compound 4, half-maximal inhibitory concentration: 91 nM
Compound 4: middle estimate off by 1.1-fold (0.06 log units), on the low side, and the stated range covers the measured number.
By their numbers in this assay, from the lowest: compounds 4, 1 and 2 (each within the scatter of the next); then compound 3.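

Replacing hydrogen with chloro on this aromatic carbon, next to the ring nitrogen and para to a large group, gives a 1.1-fold lower number from compound 2 to compound 4 (0.03 log units; within the scatter) in this assay. Among these compounds, this is the first step that isolates a single change, and it shows that this position can carry a chloro group without a shift that stands out from the scatter. No measurement at hand bears on why the added chlorine leaves the number so little changed.

Going by these compounds, it remains open whether this holds only for chloro or for the position more generally, since a single substituent cannot separate the two. An amine, a methoxy group, a nitrile or a longer alkyl chain at the same carbon could still move the number in either direction.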